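Amino for nitro on an inactive amide sulfone

The source may hold more compounds than are shown below. What is called first, only, known or untested is meant among the compounds shown, and "the series" means these compounds.

Compound 1, `COc1cc(OC)c(/C=C/S(=O)(=O)Cc2ccc(OC)c(N)c2)c(OC)c1`: 30 nM
Compound 2, `COc1ccc(CS(=O)(=O)CC(=O)Nc2c(C)cc(C)cc2C)cc1[N+](=O)[O-]`: > 30000 nM
Compound 3, `COc1cc(/C=C/S(=O)(=O)Cc2ccc(OC)c([N+](=O)[O-])c2)cc(OC)c1`: 16500 nM

In a functional assay on MDA-MB-468 cells (Homo sapiens) for cytotoxicity, read by MTT assay, with a stated time of 72 h (on this read-out lower numbers stand for stronger inhibition of growth and higher numbers for weaker inhibition of growth), compound 2 gives only > 30000 nM, which is a limit of the assay and not a number, as noted in the limit of > 30000 nM in this assay, at which 1 of the 3 values shown sits. Compound 1 gives 30 nM and compound 3 gives 16500 nM, but these two differ from each other in more than one place, so their values show only what each gives on its own.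

The change to compound 4, `COc1ccc(CS(=O)(=O)CC(=O)Nc2c(C)cc(C)cc2C)cc1N`, is amino in place of nitro on an aromatic carbon. Among the measured compounds shown here, no measured step of this kind exists among the three compounds, so the size of the step is open. Since compound 2 stands at a limit, a move is expected toward stronger inhibition in this assay, with the step of an at least 3.0-fold lower number from compound 2 to compound 4 (0.47 log units; beyond the scatter), but of uncertain size. Compound 4 is expected to give about 10000 nM, within 1000 nM to 40000 nM.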

Compound 4, concentration for 50% growth inhibition: > 30000 nM
Compound 4 ended at the assay's limit; the forecaster's own chance of this, stated with the estimate: 40%; middle value at least 3.0-fold (0.47 log units) from the limit.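

No step from compound 2 to compound 4 can be read in this assay, because both compounds stand at a limit and not at a number: the limit of > 30000 nM in this assay, at which 2 of the 4 values shown sit.

The compounds shown leave open how far amino in place of nitro on an aromatic carbon shifts growth inhibition, or whether it shifts it at all.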